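This account rests on a few compounds, and the source may have more. Where it says the series, first, only, none or still open, it means among the compounds named here.

Compound 1 `CC(C)[C@H](NC(=O)CN(c1ncnc2c1ncn2C1CCCCO1)C1CC1)C(=O)OCc1ccccc1` is one of three amides measured in a functional assay on the whole organism (Tail, strain ICR) with Mus musculus as the target, in the tail flick test, with a stated time of 90 min, at a dose of 25 umol/kg by the oral route; a lower number here means a weaker effect, a higher number a stronger effect of the compound at the dose given. In this assay compound 1 gives 30.1%, which places it second highest of the three numbers. Its nearest neighbour is compound 2 `O=C(CN(c1nc(Cl)nc2[nH]cnc12)C1CC1)NCC(=O)OCc1ccccc1`, which in this assay gives 27.2%; the two values lie within the scatter of each other. Compound 3 `O=C(CN(c1nc(Cl)nc2[nH]cnc12)C1CC1)N[C@@H](CCC(=O)OCc1ccccc1)C(=O)OCc1ccccc1` stands furthest away and in this assay gives 50%.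

Among the measured compounds shown here, the only step between measured compounds that differ in one place runs a number 22.8 percentage points higher from compound 2 to compound 3 (beyond the scatter), where 2-(benzyloxycarbonyl)ethyl replaces hydrogen on a saturated chain carbon bound to an amide-type nitrogen and a carbonyl carbon.

Compound 4 `CSCC[C@H](NC(=O)CN(c1ncnc2c1ncn2C1CCCCO1)C1CC1)C(=O)OCc1ccccc1` has not yet been measured. It differs from compound 1 in one place: 2-(methylsulfanyl)ethyl in place of isopropyl on a saturated chain carbon bound to an amide-type nitrogen and a carbonyl carbon. The change sits at the same kind of carbon as the step from compound 2 to compound 3, but there a group was added where hydrogen stood, whereas here one chain of similar size stands in for another. For the measured compounds named here, that step therefore bears only loosely on the case, and no measured pair shows this exact exchange.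

The expected step for compound 4 is a number 4.9 percentage points higher from compound 1 to compound 4 (within the scatter), small in size and uncertain in direction. Compound 4 is estimated at 35% in this assay, with a range from 15% to 58%.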

Compound 4, a percentage reported as activity, at one dose (the size of the read-out at that dose, not a potency): 42.7%
Compound 4: the middle estimate sits 7.7 percentage points below what was measured; the range from low to high includes it.
By their numbers in this assay, from the lowest: compounds 2 and 1 (each within the scatter of the next); then compounds 4 and 3 (each within the scatter of the next).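

In this assay, a number 12.6 percentage points higher from compound 1 to compound 4 (beyond the scatter), so with the core of compound 1 held fixed, the read-out depends on which chain stands on the saturated chain carbon bound to an amide-type nitrogen and a carbonyl carbon. The earlier step at this kind of carbon, a number 22.8 percentage points higher from compound 2 to compound 3 (beyond the scatter), showed only what followed when a group took the place of hydrogen, whereas this step is an exchange of one chain for another, with sulfur and one hydrogen-bond acceptor entering. No measured evidence accounts for this step.

The compounds shown leave open whether the step follows the sulfur or the change from the branched isopropyl to an unbranched chain, a question that a butyl or a 2-methoxyethyl group at this carbon would address. They also leave open whether 2-(methylsulfanyl)ethyl would give a similar step on the core of compound 2, or how 2-(benzyloxycarbonyl)ethyl would compare with it on the core of compound 1.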